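The compounds below may be only part of what the source reports. "The series", "measured", "known", "first", "only" and "open" are said of these compounds alone.

Compound 3, with the structure `COc1ccc(/C=C/C(=O)Nc2cc(C(=O)c3cc(OC)c(OC)c(OC)c3)cc(OC)c2OC)cc1`, has the lowest number among the three measured compounds in a functional assay on HT-29 cells (Homo sapiens) for cytotoxicity, read by MTT assay, with a stated time of 72 h (on this read-out lower numbers stand for stronger inhibition and higher numbers for weaker inhibition), where compound 3 gives 3800 nM. Compound 1, `COc1ccc(/C=C/C(=O)Nc2cc(C(=O)c3cc(OC)c(OC)c(OC)c3)ccc2OC)cc1`, gives 5010 nM in this assay, and the step of a 1.3-fold lower number from compound 1 to compound 3 (0.12 log units; within the scatter) is within the scatter. Compound 2, `COc1cc(/C=C/C(=O)Nc2cc(C(=O)c3cc(OC)c(OC)c(OC)c3)ccc2OC)ccc1F`, gives 7700 nM in this assay, and its number stands beyond the scatter from that of compound 3. Compound 4, `COc1cc(C(=O)c2cc(OC)c(OC)c(OC)c2)cc(NC(=O)/C=C/c2ccc(C(F)(F)F)cc2)c1OC`, has not yet been measured. It differs from compound 3 by trifluoromethyl in place of methoxy on an aromatic carbon, placed para to a large group. Among the measured compounds shown here, the one measured step that touches the same aryl ring is a 1.5-fold higher number from compound 1 to compound 2 (0.19 log units; within the scatter), a small rise within the scatter. The step of a 1.3-fold lower number from compound 1 to compound 3 (0.12 log units; within the scatter) concerns the core and does not bear on the change. On this basis only a small shift is expected, so the estimated step of a 1.3-fold higher number from compound 3 to compound 4 (0.12 log units; within the scatter) is within the scatter and compound 4 is expected to give 5000 nM in this assay, with a range from 2000 nM to 12500 nM.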

Compound 4, half-maximal inhibitory concentration: 1900 nM
Compound 4: the middle estimate sits 2.6-fold (0.42 log units) above what was measured, and the stated range ends above it.
By their numbers in this assay, from the lowest: compounds 4, 3, 1 and 2 (each within the scatter of the next, the first and the last beyond it).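

In this assay the step of a 2.0-fold lower number from compound 3 to compound 4 (0.30 log units; within the scatter) shows that the methoxy on this aromatic carbon, para to a large group, can give way to trifluoromethyl without a shift beyond the scatter. The earlier step of a 1.5-fold higher number from compound 1 to compound 2 (0.19 log units; within the scatter) left a methoxy on that ring, so compound 4 is the first of these compounds to carry no methoxy there, and its number still stays within the scatter of that of compound 3. No measurement on hand accounts for this result.

As far as these compounds go, whether an amine or a carboxylic acid on the same carbon would also stay within the scatter remains open. So does whether trifluoromethyl would behave in the same way on the core of compound 1, which has one methoxy fewer than the core of compound 3.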